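This account rests on a few compounds, and the source may have more. Where it says the series, first, only, none or still open, it means among the compounds named here.

In an ADME assay on MT4 cells (Homo sapiens) for cytotoxicity (on this read-out higher numbers stand for lower toxicity in this test and lower numbers for higher toxicity in this test), three compounds sharing one core have so far returned only limits. Compound 1 `Cc1ccccc1S(=O)(=O)n1c(=O)[nH]c2ccc(Cl)cc21` gives > 387000 nM, which is a limit. Compound 2 `Cc1cccc(S(=O)(=O)n2c(=O)[nH]c3ccc(Cl)cc32)c1` gives > 307000 nM, also a limit, and so stands with the other two rather than at a readable number. Compound 3 `Cc1ccc(C)c(S(=O)(=O)n2c(=O)[nH]c3ccc(Cl)cc32)c1` gives > 371000 nM, again a limit. The measured steps, a step that the two limits leave unreadable from compound 1 to compound 2, a step that the two limits leave unreadable from compound 1 to compound 3 and a step that the two limits leave unreadable from compound 2 to compound 3, therefore have no readable size. Compound 4 `O=c1[nH]c2ccc(Cl)cc2n1S(=O)(=O)c1cccc(C(F)(F)F)c1` carries trifluoromethyl in place of methyl on an aromatic carbon. Within the data shown here, none of the measured steps makes this exchange, so no step beyond the scatter is expected in this assay. The expected change is an at least 1.0-fold lower number from compound 2 to compound 4 (0.03 log units; that floor lies within the scatter). For compound 4 the estimate is 280000 nM, with an expected range of 80000 nM to 420000 nM.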

Compound 4, half-maximal cytotoxic concentration: > 331000 nM
Compound 4: a limit, no number; the forecaster's own chance of this, stated with the estimate: 65%; middle value at least 1.1-fold (0.07 log units) away from the limit.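

In this assay compound 4 gives > 331000 nM, which is a limit, so its step from compound 2, itself only a limit, cannot be read. The compounds shown leave open whether trifluoromethyl in place of methyl changes the half-maximal cytotoxic concentration at all.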